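This account rests on a few compounds, and the source may have more. Where it says the series, first, only, none or still open, it means among the compounds named here.

Of the compounds shown here, three with a shared core have been measured in a functional assay on HCT-116 cells (Homo sapiens) for antiproliferative activity; a higher number here means a weaker inhibitor, a lower number a stronger inhibitor. Compound 1, `CCO/N=C/c1c(N)ncnc1Oc1ccc2[nH]c(C)cc2c1F`, gives 36 nM, the lowest number of the three and therefore the strongest inhibitor among them. Compound 2, `CO/N=C/c1c(N)ncnc1Oc1ccc2cccnc2c1`, gives 2620 nM, and compound 3, `CO/N=C/c1c(N)ncnc1Oc1ccc2[nH]ccc2c1`, gives 3520 nM; each differs from compound 1 in more than one place, so their gaps show only how far they lag behind. Compound 4, `COCCCO/N=C/c1c(N)ncnc1Oc1ccc2[nH]c(C)cc2c1F`, is not yet measured. It differs from compound 1 by methoxymethyl in place of hydrogen on a saturated chain carbon, two bonds along the chain from an oxygen on an unsaturated carbon. Among the measured compounds shown here, the chain simply grows longer, and none of the measured compounds tests such a change. The expected step is a 1.5-fold higher number from compound 1 to compound 4 (0.18 log units; within the scatter), a small shift within or close to the scatter. Compound 4 is estimated at 55 nM, between 15 nM and 200 nM.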

Compound 4, half-maximal inhibitory concentration: 438 nM
Estimate against measurement, compound 4: 8.0-fold (0.90 log units) below; the measured number lies above the stated range.
By their numbers in this assay, from the lowest: compound 1; then compound 4; then compounds 2 and 3 (each within the scatter of the next).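

In this assay, extending ethoxy to 3-methoxypropoxy gives a 12-fold higher number from compound 1 to compound 4 (1.09 log units; beyond the scatter). Among the compounds shown here, this shows that the oxime side chain of compound 1 does not accept this added methoxymethyl freely, which the earlier compounds could not show, as none of them isolates a change at this position. Nothing at hand explains the size of this step.

Going by these compounds, it remains open whether chain length or the added oxygen matters more. A plain butoxy chain would help separate the two, and a chain ending in an amine would show how a different end group fares.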